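This account rests on a few compounds, and the source may have more. Where it says the series, first, only, none or still open, it means among the compounds named here.

Measured so far in a functional assay on HepG2 cells (Homo sapiens) for cytotoxicity, read by sulforhodamine B assay, with a stated time of 24 h; on this read-out higher numbers stand for weaker inhibition and lower numbers for stronger inhibition:

Compound 1, `S=C(Nc1ccc(Cl)cc1)Nn1c(S)nnc1-c1ccncc1`, gives 2020 nM.
Compound 2, `COc1ccc(NC(=S)Nn2c(S)nnc2-c2ccncc2)cc1`, gives 1300 nM.
Compound 3, `Clc1ccc(Nc2nn3c(-c4ccncc4)nnc3s2)cc1`, gives 1980 nM.

Compounds 1 and 2 share one core and differ in a single place: methoxy in place of chloro on an aromatic carbon. This change gave a 1.6-fold lower number from compound 1 to compound 2 (0.19 log units; within the scatter), a step that stays within the usual scatter of repeated measurements, so the two compounds cannot be ranked against each other on this evidence.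

Compound 3 carries a different core; the difference between the two cores is not broken down here. Its value and that of compound 1 lie within the scatter of each other, as do its value and that of compound 2.

Compound 4, `COc1ccc(Nc2nn3c(-c4ccncc4)nnc3s2)cc1`, has not yet been tested in this assay. It stands to compound 3 as compound 2 stands to compound 1: methoxy in place of chloro on an aromatic carbon. The place of the change is described in the same words in both pairs, so it is the same change applied to the second core.

Because the first pair gave a 1.6-fold lower number from compound 1 to compound 2 (0.19 log units; within the scatter), the step from compound 3 to compound 4 is expected to be about a 1.6-fold lower number from compound 3 to compound 4 (0.20 log units; within the scatter), a step of similar size in this assay. Compound 4 is therefore estimated at 1250 nM, most likely between 600 nM and 2600 nM. Only the measurement can tell whether the second core behaves the same way.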

Compound 4, half-maximal inhibitory concentration: 333 nM
For compound 4 the middle estimate is 3.8-fold (0.57 log units) above the measured one; measured number outside the range, below it.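

In this assay, methoxy in place of chloro on an aromatic carbon of the second core gave a 5.9-fold lower number from compound 3 to compound 4 (0.77 log units; beyond the scatter), so on this core the change has a clear effect. The step seen on the core of compound 1 did not carry over at the same size to the second core: the same change on two cores in this assay, a 1.6-fold lower number (0.19 log units; within the scatter) from compound 1 to compound 2 and a 5.9-fold lower number (0.77 log units; beyond the scatter) from compound 3 to compound 4, 3.8-fold (0.58 log units) apart, beyond the scatter of two such steps. Among the compounds shown here, this shows that, for these two pairs, a step measured on one core is a poor guide to its size on the other, but it does not show which part of the cores makes the difference or why, and with only one of the two steps beyond the scatter, it does not establish a shared direction.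

The compounds shown carry only chloro and methoxy at this place, so it remains open how a hydroxyl, an amine or a longer chain such as ethoxy would behave on either core. A third pair of cores would also be needed to tell how often the step changes size from core to core.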